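A few compounds are considered here, and "the series" means these few. Any claim that something is new, unique, unknown or untested is made for them only; others in the source may bear on it.

In a functional assay on CLL cells (Homo sapiens) for cytotoxicity, read by MTT assay, with a stated time of 48 h (a lower number here means that less compound is needed, a higher number that more compound is needed for the effect), compound 1 (`C=C(CC)C(=O)c1ccc(OCC(=O)Nc2ccc(C(=O)O)cn2)c(Cl)c1Cl`) gives 14900 nM and compound 2 (`C=C(CC)C(=O)c1ccc(OCC(=O)Nc2ccc(O)c(Cl)c2)c(Cl)c1Cl`) gives 5500 nM, while compound 3 (`C=C(CC)C(=O)c1ccc(OCC(=O)Nc2ccc(CC(=O)O)cc2)c(Cl)c1Cl`) stands at 3200 nM on the shared core. Compound 3 thus lies within the scatter of compound 2, and its number is well under that of compound 1. Compound 4 (`C=C(CC)C(=O)c1ccc(OCC(=O)Nc2ccc(O)cc2)c(Cl)c1Cl`) carries hydroxy in place of carboxymethyl on an aromatic carbon, para to a large group (hydroxy in place of carboxymethyl on an aromatic carbon). Within the data shown here, the one measured step bearing on this is a 2.7-fold lower number from compound 1 to compound 2 (0.43 log units; beyond the scatter) and it brings in 3-chloro-4-hydroxyphenyl, the nearest group to that of compound 4. With compound 2 at 5500 nM no change beyond the scatter is expected in this assay for this swap. The estimated step is a 1.4-fold higher number from compound 3 to compound 4 (0.15 log units; within the scatter) and stays within the scatter. The estimated value for compound 4 is 4500 nM (2000 nM to 10000 nM).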

Compound 4, half-maximal effective concentration: 6400 nM
For compound 4 the middle estimate is 1.4-fold (0.15 log units) below the measured one; the range from low to high includes it.
By their numbers in this assay, from the lowest: compounds 3, 2 and 4 (each within the scatter of the next); then compound 1.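

With hydroxy in place of carboxymethyl on the aromatic carbon, this assay gives a 2.0-fold higher number from compound 3 to compound 4 (0.30 log units; within the scatter), so this position accepts a single-atom group as well as the four-atom chain with no change beyond the scatter. Hydrogen in place of chloro gives a 1.2-fold higher number from compound 2 to compound 4 (0.07 log units; within the scatter), so the chloro shows no effect beyond the scatter either. The 4-hydroxyphenyl group also separates from 5-carboxypyridin-2-yl, with a 2.3-fold lower number from compound 1 to compound 4 (0.37 log units; beyond the scatter).

No evidence on hand accounts for these steps. As far as these compounds go, whether an amine or a longer carboxylic acid chain at this position would stay within the scatter remains open.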